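From 1-methylpyrrolidin-3-yl to 2-(isobutylamino)ethyl in compound 2

The source may report more compounds than this note shows. Statements on the series, on what has been measured and on what is new or still open speak of the compounds shown alone.

In a functional assay on SK-BR-3 cells (Homo sapiens) for antiproliferative activity (a lower number here means a stronger inhibitor, a higher number a weaker inhibitor), compound 2 `CC(C)=CCc1cc(C(=O)Nc2cc3ccc(OCC4CCN(C)C4)c(C)c3oc2=O)ccc1O` gives 920 nM, within the scatter of compound 1 `CC(=O)Oc1ccc(C(=O)Nc2cc3ccc(OCC4CCCN(C)C4)c(C)c3oc2=O)cc1CC=C(C)C` at 740 nM. Within the data shown here, those two compounds differ in more than one place, so no measured step isolates a side-chain change. Compound 3 `CC(C)=CCc1cc(C(=O)Nc2cc3ccc(OCCCNCC(C)C)c(C)c3oc2=O)ccc1O` differs from compound 2 by 2-(isobutylamino)ethyl in place of 1-methylpyrrolidin-3-yl on a saturated chain carbon bound to an oxygen on an aromatic ring, with the ring given up for an open chain on a saturated chain carbon bound to an oxygen on an aromatic ring. In this assay the expected 1.2-fold lower number from compound 2 to compound 3 (0.09 log units; within the scatter) stays within the scatter, with no firm direction. For compound 3 the estimated value is 750 nM, with an expected range of 280 nM to 2000 nM.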

Compound 3, half-maximal inhibitory concentration: 1030 nM
Compound 3: the middle estimate sits 1.4-fold (0.14 log units) below what was measured; low and high end bracket the measured number.
By their numbers in this assay, from the lowest: compounds 1, 2 and 3 (each within the scatter of the next).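

In this assay the step of a 1.1-fold higher number from compound 2 to compound 3 (0.05 log units; within the scatter) lies within the scatter, so compound 2 and compound 3 cannot be told apart. At this position on a saturated chain carbon bound to an oxygen on an aromatic ring, the 1-methylpyrrolidin-3-yl ring can therefore be given up for the open 2-(isobutylamino)ethyl chain, with its added hydrogen-bond donor, without a readable effect on the number.

Whether this holds for a side chain ending in a carboxylic acid or a morpholine, rather than an amine of the kind shown here, remains open. No supporting data bear on why the two groups read alike.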